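A few compounds are considered here, and "the series" means these few. Any claim that something is new, unique, unknown or untested is made for them only; others in the source may bear on it.

Measured so far in an ADME assay on HPLF cells (Homo sapiens) for cytotoxicity, with a stated time of 48 h; a lower number here means that less compound is tolerated, a higher number that more compound is tolerated:
compound 1 `Cc1c(C(=O)/C=C/c2cccc([N+](=O)[O-])c2)[n+]([O-])c2ccccc2[n+]1[O-]` with 18000 nM
compound 2 `COc1ccc(/C=C/C(=O)c2c(C)[n+]([O-])c3ccccc3[n+]2[O-])cc1OC` with 156000 nM
compound 3 `Cc1c(C(=O)/C=C/c2ccc(Cl)c(Cl)c2)[n+]([O-])c2ccccc2[n+]1[O-]` with 5700 nM

Compound 3 stands at the lowest of the three numbers; compound 1 lies above it beyond the scatter, and compound 2 further above still. Compound 4 `Cc1c(C(=O)/C=C/c2ccc(Br)cc2)[n+]([O-])c2ccccc2[n+]1[O-]` has not been measured. It differs from compound 3 in one place: 4-bromophenyl in place of 3,4-dichlorophenyl on a double-bonded chain carbon bound to a double-bonded chain carbon. Going by the values given here, no step between measured compounds bears on this exchange, so its size is open. Among the compounds with values here, a modest upward step is expected, as compound 1 with 18000 nM and compound 2 with 156000 nM both sit above compound 3, the sole member carrying two ring substituents. Compound 4 is expected at 11000 nM, within 4000 nM to 35000 nM, a step of a 1.9-fold higher number from compound 3 to compound 4 (0.29 log units; within the scatter).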

Compound 4, half-maximal cytotoxic concentration: 26000 nM
Estimate against measurement, compound 4: 2.4-fold (0.37 log units) below; low and high end bracket the measured number.
By their numbers in this assay, from the lowest: compound 3; then compounds 1 and 4 (each within the scatter of the next); then compound 2.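

In this assay, 4-bromophenyl in place of 3,4-dichlorophenyl on a double-bonded chain carbon bound to a double-bonded chain carbon gives a 4.6-fold higher number from compound 3 to compound 4 (0.66 log units; beyond the scatter). Going by these compounds alone, this is the first single-place step, and it shows that this position alone can move the tolerated concentration beyond the scatter while the shared core stays unchanged. Nothing at hand explains the step.

The halogen exchange and the loss of a ring substituent remain tangled in this one step. Unsubstituted phenyl or 4-chlorophenyl at this position would separate them, and a dimethylamino-substituted phenyl would test a different kind of group there.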